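Working notes: adding bromo to compound 2

The source may report more compounds than this note shows. Statements on the series, on what has been measured and on what is new or still open speak of the compounds shown alone.

compound 1 `O=C(CCCCC1CCSS1)NO` gives 7.92%
compound 2 `O=C(CCCCC1CCSS1)Nc1ccccn1` gives "not active" (no number reported)
compound 3 `O=C(CCCCC1CCSS1)Nc1ccc(Br)cn1` awaits measurement

In a functional assay on KB cells (Homo sapiens) for inhibition, read by MTT assay, with a stated time of 24 h, tested at 0.1 ug/mL (on this read-out lower numbers stand for less inhibition of growth and higher numbers for more inhibition of growth at the one concentration tested), compound 2 is reported as "not active" (no number reported) and so has no single number to start from. The structural change runs bromo in place of hydrogen on an aromatic carbon and puts bromo in place of hydrogen on an aromatic carbon. Going by the values given here, no measured pair gauges this change, so no step beyond the usual scatter is expected in this assay and no direction is favoured with confidence. Compound 3 is estimated at 6% with an expected range from 0% to 18% on this read-out.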

Compound 3, percent growth inhibition at one concentration: "not active" (no number reported)
No number was reported for compound 3, and the estimate cannot be compared.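

In this assay compound 2 and compound 3 are both reported as "not active" with no number, so no step can be read between them. On these data alone, whether bromo in place of hydrogen changes growth inhibition at all stays open. No evidence bears on this result.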